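Piperazinylpyridine series: chloro for vinyloxy on the aromatic ring

This account rests on a few compounds, and the source may have more. Where it says the series, first, only, none or still open, it means among the compounds named here.

Two members of this series have numbers in an assay on HEK293 cells with Neuronal acetylcholine receptor; alpha4/beta2 (Homo sapiens) as the target, read by FLIPR and calcium flux; a lower number here means a smaller maximal response, a higher number a larger maximal response. Compound 1 `C=COc1cncc(N2CCNCC2)c1` gives 18% in this assay, and compound 2 `COc1cc(N2CCNCC2)cnc1Br` gives 68%. Compound 1 thus stands at the bottom of the two numbers shown, and the gap to compound 2 is well beyond the usual scatter. For the measured compounds named here, no single-point step between measured compounds is available, so the two values can only be placed side by side, not read as a change attributable to one group.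

Compound 3 `Clc1cncc(N2CCNCC2)c1` has not yet been measured in this assay. Its difference from compound 1 is chloro in place of vinyloxy on an aromatic carbon. With nothing in the series that isolates this exchange, the expectation rests on compound 1 alone, which gives a small maximal response of 18%, leaving room for movement mainly upward. An upward step beyond the scatter is expected, of moderate size, expressed as a number 27 percentage points higher from compound 1 to compound 3 (beyond the scatter). Compound 3 is estimated at 45%, with a range from 15% to 80%.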

Compound 3, largest response reached (reported as efficacy), in percent of the reference or control that the assay uses: 41%
Compound 3: middle estimate off by 4 percentage points, on the high side; measured number inside the range.
By their numbers in this assay, from the lowest: compound 1; then compound 3; then compound 2.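

In this assay, for the compounds shown here, chloro in place of vinyloxy on the aromatic carbon two atoms from the ring nitrogen gives a number 23 percentage points higher from compound 1 to compound 3 (beyond the scatter) and provides the first reading that isolates a single place. The maximal response therefore depends on the group at this position, and neither the oxygen nor the double bond of vinyloxy is needed to reach the level of compound 3, since a single chlorine atom with no hydrogen-bond acceptor stands there instead. Nothing measured here speaks to why the exchange raises the response.

Going by these compounds alone, the single step cannot separate a gain tied to chloro itself from a gain tied to the loss of vinyloxy, and fluoro, ethoxy or a primary amine on the same aromatic carbon of the shared core would help to tell these two readings apart. Going by these compounds, it also remains open whether a step of this kind would carry over to a core with a second substituent on the ring, as the core of compound 2 has.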